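A few compounds are considered here, and "the series" means these few. Any claim that something is new, unique, unknown or untested is made for them only; others in the source may bear on it.

In a functional assay on the whole organism (strain Sprague-Dawley) for inhibition, with Rattus norvegicus as the target, with a stated time of 10 min (on this read-out lower numbers stand for an effect already at smaller amounts and higher numbers for an effect only at larger amounts of compound), compound 1 (`CCOC(=O)c1cnc(-c2ccccc2OC)[nH]c1=O`) gives 10 mg/kg and compound 2 (`CCOC(=O)c1ccc(OCC)c(-c2ncc(C(=O)OCC)c(=O)[nH]2)c1`) gives 1 mg/kg as the lower of the two numbers, a gap beyond the usual scatter. Compound 3 (`CCOC(=O)c1cnc(-c2cc(S(=O)(=O)N(C)C)ccc2OCC)[nH]c1=O`) is still unmeasured and differs from compound 2 by dimethylsulfamoyl in place of ethoxycarbonyl on an aromatic carbon. Going by the values given here, no measured step covers this exchange, so the expectation rests on compound 2 at 1 mg/kg as the nearest measured structure, and no shift beyond the scatter is expected in this assay for this change. The expected step is a 1.5-fold higher number from compound 2 to compound 3 (0.18 log units; within the scatter) and remains an estimate. Compound 3 is estimated at 1.5 mg/kg (expected range 0.4 mg/kg to 6 mg/kg).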

Compound 3, dose for 50% inhibition: 50 mg/kg
Compound 3: the middle estimate sits 33-fold (1.52 log units) below what was measured; measured number above the stated range.
By their numbers in this assay, from the lowest: compound 2; then compound 1; then compound 3.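

In this assay, dimethylsulfamoyl in place of ethoxycarbonyl gives a 50-fold higher number from compound 2 to compound 3 (1.70 log units; beyond the scatter). The read-out therefore depends strongly on the group at this aromatic carbon, meta to a large group and para to an ethoxy group, although the two groups match in hydrogen-bond donors, hydrogen-bond acceptors and net charge. Nothing at hand explains the size of this step.

Open, as far as these compounds go, is whether a carboxylic acid or a primary amide at this carbon would stay close to compound 2 or shift like compound 3. Also open, from the compounds shown here alone, is whether a longer chain on the ester of this group would change the number.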